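The compounds below may be only part of what the source reports. "The series", "measured", "known", "first", "only" and "open" are said of these compounds alone.

Compound 1 `COc1ccc(N/C=C\C(=O)c2nc(-c3ccc(F)cc3)n3ccccc23)cc1` in a functional assay on B16-F10 cells (Mus musculus) for cytotoxicity, read by MTT assay, with a stated time of 48 h (on this read-out higher numbers stand for weaker inhibition and lower numbers for stronger inhibition), gives 2560 nM.
Compound 2 `O=C(/C=C\Nc1ccc(F)cc1)c1nc(-c2ccc(C(F)(F)F)cc2)n2ccccc12` gives in this assay only a limit, > 30000 nM.

Among the two results shown, compound 1 holds the only numerical value; the other, (the limit of > 30000 nM in this assay, at which 1 of the 2 values shown sits), is a limit rather than a number. Compound 3 `O=C(/C=C\Nc1ccc(Cl)cc1)c1nc(-c2ccc(F)cc2)n2ccccc12` differs from compound 1 by chloro in place of methoxy on an aromatic carbon. Among the compounds with values here, no measured pair carries this change, so nothing here fixes its size or direction. The expected step is a 1.0-fold lower number from compound 1 to compound 3 (0.01 log units; within the scatter), which amounts to no change beyond the usual scatter. Compound 3 is accordingly estimated at 2500 nM, with a range from 800 nM to 8000 nM.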

Compound 3, half-maximal inhibitory concentration: 11000 nM
Estimate against measurement, compound 3: 4.4-fold (0.64 log units) below; the measured number lies above the stated range.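

In this assay the change from 4-methoxyphenyl to 4-chlorophenyl gives a 4.3-fold higher number from compound 1 to compound 3 (0.63 log units; beyond the scatter) and so provides the first measured size and direction for this change. It shows that this place on the ring, para to a large group, responds to its substituent, with methoxy giving the stronger inhibition of the two groups. Nothing shown gives a reason for this step.

Still open, from the compounds shown here alone, is how a hydroxyl, an amine or a carboxylic acid would read at this place. Also open, going by these compounds, is whether the same step would hold if the 4-fluorophenyl group on the core were replaced.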